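Acetyl on the Ring Oxygen: From Compound 2 to Compound 3

This account rests on a few compounds, and the source may have more. Where it says the series, first, only, none or still open, it means among the compounds named here.

Compound 1, `C=CC[N+](C)(C)c1cccc(OC(C)=O)c1`, in a functional assay with Cavia porcellus as the target; a lower number here means a stronger inhibitor, a higher number a weaker inhibitor: 3870 nM
Compound 2, `C[N+](C)(Cc1ccccc1)c1cccc(O)c1`, in this assay: a limit, > 3000 nM

Where compound 2 stands can only be given as a limit. In this assay, among the measured compounds shown here, compound 2 reaches > 3000 nM, which is a limit of the measurement and not a number, so the result says only that compound 2 is a weak inhibitor here. The line the limit of > 3000 nM in this assay, at which 1 of the 2 values shown sits, shows how many of the values sit at that limit.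

Compound 3, `CC(=O)Oc1cccc([N+](C)(C)Cc2ccccc2)c1`, differs from compound 2 in one place: acetyl in place of hydrogen on an oxygen on an aromatic ring. For the measured compounds named here, no measured pair shows this change by itself, so there is no step to lean on. Compound 1 also carries an acetyl on its ring oxygen, and in this assay compound 1 gives 3870 nM, a weak value. The step is therefore expected to be a step that the limit leaves unreadable from compound 2 to compound 3, within the usual scatter, leaving compound 3 weak. For compound 3 the estimated value is 4000 nM, with a range from 1500 nM to 12000 nM.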

Compound 3, half-maximal inhibitory concentration: > 3000 nM
Compound 3 ended at the assay's limit; the forecaster's own chance of this, stated with the estimate: 40%; the middle value is on the limit's open side.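

Compound 3 gives only a limit in this assay, so no step from compound 2 or compound 1 to compound 3 can be read: the limit of > 3000 nM in this assay, at which 2 of the 3 values shown sit.

As far as these compounds go, it stays open whether acetyl in place of hydrogen on an oxygen on an aromatic ring changes inhibition at all, and how weak compound 2 and compound 3 really are.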